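The compounds below may be only part of what the source reports. "The series", "measured", "known", "first", "only" and "open" are said of these compounds alone.

Of the compounds shown here, three built on a shared core have so far been tested in a functional assay on DU-145 cells (Homo sapiens) for inhibition, read by trypan blue exclusion, with a stated time of 72 h; on this read-out higher numbers stand for weaker inhibition and lower numbers for stronger inhibition. There, compound 1 (`Cn1c(=O)c(C(=O)Nc2ccc(F)cc2F)cc2cnc(Nc3ccc4[nH]ccc4c3)nc21`) gives 5000 nM, compound 3 (`COc1ccc(S(=O)(=O)c2cc3cnc(Nc4cccc5[nH]ccc45)nc3n(C)c2=O)cc1`) gives 5000 nM, and compound 2 (`Cn1c(=O)c(S(=O)(=O)c2ccc(F)cc2F)cc2cnc(Nc3ccc4sccc4c3)nc21`) gives 500 nM. Compound 2 therefore holds the lowest number of the three and shows the strongest inhibition, with its distance to each of the other two beyond the scatter.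

Compound 4 (`Cn1c(=O)c(S(=O)(=O)c2ccc(F)cc2F)cc2cnc(Nc3ccccn3)nc21`) is compound 2 with one change: pyridin-2-yl in place of 1-benzothiophen-5-yl on a nitrogen on an aromatic ring. In words, pyridin-2-yl stands in place of 1-benzothiophen-5-yl on a nitrogen on an aromatic ring.

For the measured compounds named here, no pair of measured compounds differs in one place only, so the data contain no direct precedent for this change. The evidence is indirect and thin: compound 2 reaches 500 nM, while compound 1 and compound 3, which differ from it in more than this one group, both sit higher. On that basis, some of the standing of compound 2 is expected to be lost with the 1-benzothiophen-5-yl group. The estimate is a move towards weaker inhibition, an 8.0-fold higher number from compound 2 to compound 4 (0.90 log units; beyond the scatter), which would lie beyond the scatter. For compound 4 in this assay, the expected value is 4000 nM, with an estimated range of 1000 nM to 15000 nM.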

Compound 4, half-maximal inhibitory concentration: 75000 nM
The estimate for compound 4 lay 19-fold (1.27 log units) below the measured number; the measured number lies above the stated range.
By their numbers in this assay, from the lowest: compound 2; then compounds 1 and 3 (each within the scatter of the next); then compound 4.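

In this assay, for the compounds shown here, the step of a 150-fold higher number from compound 2 to compound 4 (2.18 log units; beyond the scatter) gives the first direct reading at this position, with the rest of the molecule unchanged. It shows that the group on this nitrogen on an aromatic ring strongly affects inhibition here: the change from (1-benzothiophen-5-yl)amino to (pyridin-2-yl)amino replaces one five-membered and one six-membered aromatic ring with a single six-membered aromatic ring, and the large loss occurs with no change in the counted hydrogen-bond donors, hydrogen-bond acceptors or net charge of the group. The available data offer no measurement that accounts for the size of this step.

This single step changes the ring count, the size of the group and its hetero atom together, so it cannot show which of these matters; a plain phenyl group or a quinolin-6-yl group on the same nitrogen would begin to separate them. As far as these compounds go, whether the change would cost as much with the amide of compound 1 in place of the sulfonyl-linked group also remains open.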